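Bromo anilines on the shared core: tert-butyl to methoxy

This account rests on a few compounds, and the source may have more. Where it says the series, first, only, none or still open, it means among the compounds named here.

Compound 1 `CCN(c1nc(C)cc(C)n1)c1ccc(C(C)(C)C)cc1Br` is tested in an assay on isolated protein for binding affinity to corticotropin-releasing factor receptor 1 (Homo sapiens) (a higher number here means a weaker inhibitor, a lower number a stronger inhibitor), and gives only a limit there, > 100 nM; of the values in hand it sits at the limit of > 100 nM in this assay, at which 1 of the 3 values shown sits. Compound 2 `CCN(CC)c1nc(C)nc(N(CC)c2ccc(C(C)=O)cc2Br)n1`, built on a different core, gives 17 nM in this assay. Compound 3 `CCN(c1ccc(C(C)C)cc1)c1nc(C)cc(C)n1` returns only a limit in this assay, > 1000 nM, which is the limit of > 1000 nM in this assay, at which 1 of the 3 values shown sits. Compound 4 `CCN(c1nc(C)cc(C)n1)c1ccc(OC)cc1Br` differs from compound 1 in one place: methoxy in place of tert-butyl on an aromatic carbon. For the measured compounds named here, no measured pair isolates this change, so the step from compound 1 can only be guessed; with compound 1 at a limit, a real number for compound 4 would itself count as a gain. Compound 4 is estimated at 40 nM in this assay, within 8 nM to 300 nM. The expected step of an at least 2.5-fold lower number from compound 1 to compound 4 (0.39 log units; beyond the scatter) is taken as beyond the scatter, toward stronger binding.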

Compound 4, inhibition constant: 35 nM
Compound 4: the middle estimate sits 1.1-fold (0.06 log units) above what was measured; the measured number falls inside the stated range.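

On the shared core, this position on the aromatic ring gives a real number once methoxy replaces tert-butyl, a step of an at least 2.8-fold lower number from compound 1 to compound 4 (0.45 log units; beyond the scatter) in this assay. For the compounds shown here, it is the first change that can be read at this position, and it shows that tert-butyl is not needed there for binding. Compound 1 is held only at a limit, so the step has a floor but no known size: the limit of > 100 nM in this assay, at which 1 of the 4 values shown sits.

From the compounds shown here alone, whether the oxygen of methoxy or simply the loss of tert-butyl carries the step stays open. Also open, going by these compounds, is how an amine or a longer chain such as ethoxy would read at this position.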